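A few compounds are considered here, and "the series" means these few. Any claim that something is new, unique, unknown or untested is made for them only; others in the source may bear on it.

Compound 3, `CC1CCN(S(=O)(=O)N2CCN(CC(=O)Nc3ccc(Cl)cc3)CC2)CC1`, is the starting point of this step. In an assay on HEK293 cells for activation of potassium channel subfamily T member 1 (Homo sapiens), read by thallium flux (on this read-out higher numbers stand for an effect only at larger amounts of compound and lower numbers for an effect already at smaller amounts), compound 3 gives > 10000 nM, which is a limit of the assay and not a number; the limit of > 10000 nM in this assay, at which 1 of the 3 values shown sits, marks where it sits. Two other compounds of the same series give numbers. Compound 1, `COc1ccc(Cl)cc1NC(=O)CC1CCN(S(=O)(=O)N2CCC(C)CC2)CC1`, gives 9300 nM in this assay, and compound 2, `COc1ccc(Cl)cc1NC(=O)N1CCC2(CC1)CN(S(=O)(=O)N1CCC(C)CC1)C2`, gives 10000 nM. These two values lie within the usual scatter of each other, and compound 3 sits at the limit beside them, so nothing among the three compounds points to a clear order in this assay.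

Compound 4, `CC1CCN(S(=O)(=O)N2CCN(CC(=O)Nc3cc(Cl)ccc3F)CC2)CC1`, is the compound not yet measured. It differs from compound 3 in one place: 5-chloro-2-fluorophenyl in place of 4-chlorophenyl on an amide-type nitrogen. Within the data shown here, no measured pair in this set reports the same change, so its size is not known from these data.

Given that compound 3 sits at the limit with > 10000 nM, compound 4 is expected to remain in the same weak region, with the step from compound 3 to compound 4 estimated at a step that the limit leaves unreadable from compound 3 to compound 4, that is, no step beyond the scatter in either direction. Compound 4 is therefore estimated at 12000 nM in this assay, within a range from 5000 nM to 30000 nM, and a reading that is again only a limit is quite possible.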

Compound 4, half-maximal effective concentration: 3800 nM
For compound 4 the middle estimate is 3.2-fold (0.50 log units) above the measured one, outside the stated range (below it).
By their numbers in this assay, from the lowest: compound 4; then compounds 1 and 2 (each within the scatter of the next).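

In this assay, among these compounds, the change from 4-chlorophenyl to 5-chloro-2-fluorophenyl on an amide-type nitrogen gives an at least 2.6-fold lower number from compound 3 to compound 4 (0.42 log units; beyond the scatter), the only readable step in this set and the first sign that the assay responds to the aryl group at this place. Compounds 1 and 2 differ from compound 3 in more than one place, so they could not show this. For compound 3 the value > 10000 nM is a limit of the assay and not a number, so the step fixes only a minimum size, and its full size stays unread: the limit of > 10000 nM in this assay, at which 1 of the 4 values shown sits.

The change alters two things at once, as a fluorine enters the ring and the chlorine stands at a different ring position, and the compounds shown do not tell which of these goes with the lower number. Simple phenyl rings such as 3-chlorophenyl, 2-fluorophenyl or 2,5-dichlorophenyl on the same amide-type nitrogen would separate these two contributions, and whether 5-chloro-2-fluorophenyl has a similar effect on the cores of compound 1 or compound 2 also remains open.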